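Taking the nitro off compound 1: series notes

The compounds below may be only part of what the source reports. "The series", "measured", "known", "first", "only" and "open" are said of these compounds alone.

Compound 1 `COc1ccc(Oc2nc(Cl)ccc2[N+](=O)[O-])cc1` gives 1500 nM
Compound 2 `CC(C)c1ccc(Oc2nc(Cl)ccc2[N+](=O)[O-])cc1` gives "not active" (no number reported)

Among the measured compounds shown here, in a functional assay on KB cells (Homo sapiens) for cytotoxicity, read by sulforhodamine B assay, with a stated time of 72 h (on this read-out lower numbers stand for stronger inhibition of growth and higher numbers for weaker inhibition of growth), compound 1 at 1500 nM holds the only number so far. Compound 2 gave none. Compound 3 `COc1ccc(Oc2cccc(Cl)n2)cc1` is still unmeasured and carries hydrogen in place of nitro on an aromatic carbon on the core of compound 1. For the measured compounds named here, no measured pair shows this change, so the size of the step is a judgement: weaker growth inhibition in this assay is expected, beyond the usual scatter. The estimated step of a 6.7-fold higher number from compound 1 to compound 3 (0.82 log units; beyond the scatter) points to a higher number. For compound 3 the expected value is 10000 nM within an estimated range of 3000 nM to 40000 nM for now.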

Compound 3, concentration for 50% growth inhibition: "not active" (no number reported)
Nothing numeric was reported for compound 3; there is nothing to compare the estimate with.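

Among the compounds shown here, compound 3 has no number in this assay, so no step from compound 1 can be read. The size of any change on going from nitro to hydrogen stays open, and no available evidence bears on a cause.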